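The source may hold more compounds than are shown below. What is called first, only, known or untested is meant among the compounds shown, and "the series" means these compounds.

Compound 2 `COc1cc2nc(N3CCCN(C(=O)N4CCOCC4)CC3)cc(N)c2c(-c2ccccc2)c1OC` in an in vitro ADME assay on microsomes from liver (Homo sapiens) for metabolic stability, tested at 1 uM (on this read-out higher numbers stand for a longer-lived compound and lower numbers for a shorter-lived compound), gives 0.15 h. Compound 1 `COc1cc2nc(N3CCCN(C(=O)N4CCOCC4)CC3)nc(N)c2c(-c2ccccn2)c1OC` in this assay gives 0.15 h, so compound 1 and compound 2 fall within the scatter of each other and together sit at the low end of the three numbers. Compound 3 `COc1cc2nc(N3CCc4ncccc4C3)nc(N)c2c(-c2ncccn2)c1OC` in this assay gives 0.517 h, a gap from compound 2 that lies beyond the scatter. Among the compounds with values here, no pair among the measured compounds differs in a single place, so no isolated step is available as a guide.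

Compound 4 `COc1cc2nc(N3CCCN(C(=O)N4CCOCC4)CC3)cc(N)c2c(-c2ccc(F)cc2)c1OC` has not yet been measured. Compound 4 differs from compound 2 by fluoro in place of hydrogen on an aromatic carbon. Within the data shown here, no measured pair in this set carries that change, so its size cannot be read from the data. Starting from compound 2 at 0.15 h, a small rise or no change beyond the scatter is expected. The expected step is a 1.5-fold higher number from compound 2 to compound 4 (0.17 log units; within the scatter). Compound 4 is therefore estimated to give 0.22 h in this assay, within a range from 0.1 h to 0.5 h.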

Compound 4, half-life in the Homo sapiens assay: 0.1 h
For compound 4 the middle estimate is 2.2-fold (0.34 log units) above the measured one, within the range that was stated.
By their numbers in the Homo sapiens assay, from the lowest: compounds 4, 1 and 2 (each within the scatter of the next); then compound 3.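

Phenyl to 4-fluorophenyl is the first change in this series that stands alone at one place, and in the Homo sapiens assay it reads as a 1.5-fold lower number from compound 2 to compound 4 (0.18 log units; within the scatter) so fluoro in place of hydrogen at this carbon does not separate the pair on half-life. In a physicochemical assay for lipophilicity, in phosphate buffer, at pH 7.4 (a higher number here means a more lipophilic compound, a lower number a more polar compound), the same change reads as no change at the digits printed from compound 2 to compound 4 (within the scatter) with compound 2 at 1.8 and compound 4 at 1.8 so the distribution coefficient does not separate the pair either. No measurement at hand offers an explanation for these results.

Going by these compounds, whether a methoxy group or a nitrile at this same place would shift either read-out beyond the scatter remains open. Also open, on these data alone, is whether the step would hold on the different cores of compound 1 and compound 3.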